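The source may report more compounds than this note shows. Statements on the series, on what has been measured and on what is new or still open speak of the compounds shown alone.

Measured so far in an assay on isolated protein with malate dehydrogenase, mitochondrial (Sus scrofa) as the target; a lower number here means a stronger inhibitor, a higher number a weaker inhibitor:
compound 1 `O=C(O)c1cnc2cc(OCCc3ccc(Br)cc3)ccc2c1O` — 2510 nM
compound 2 `CN(C)c1ccc2c(O)c(C(=O)O)cnc2c1` — 479000 nM
compound 3 `O=C(O)c1cnc2cc(OCCc3ccccc3)ccc2c1O` — 38000 nM

Compound 3 stands second highest of the three numbers in this assay. Among the measured compounds shown here, compound 1 is the nearest structural neighbour, and the step of a 15-fold higher number from compound 1 to compound 3 (1.18 log units; beyond the scatter) is the one directly informative step in the set. For the measured compounds named here, compound 2 carries a different substituent on the shared core altogether and gives 479000 nM; it shares no single-point step with compound 3 and is set aside here.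

Compound 4 `O=C(O)c1cnc2cc(OCCOc3ccc(Br)cc3)ccc2c1O` is not yet measured. Relative to compound 3 the change is 4-bromophenoxy in place of phenyl on a saturated chain carbon, two bonds along the chain from an oxygen on an aromatic ring. Two things happen at once: the bromo that was removed in the step from compound 1 to compound 3 comes back, and an oxygen is added to the chain. Only the first has a measured counterpart, a 15-fold higher number from compound 1 to compound 3 (1.18 log units; beyond the scatter), which was large. On these data alone, the second has none, so its effect on this assay is unknown.

Compound 4 is therefore expected to give a lower number than compound 3, estimated at 4000 nM (range 1000 nM to 16000 nM), a step of a 9.5-fold lower number from compound 3 to compound 4 (0.98 log units; beyond the scatter), because a 15-fold higher number from compound 1 to compound 3 (1.18 log units; beyond the scatter) ran in the opposite direction; the range is widened for the untested chain oxygen.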

Compound 4, half-maximal inhibitory concentration: 5130 nM
For compound 4 the middle estimate is 1.3-fold (0.11 log units) below the measured one; the range from low to high includes it.
By their numbers in this assay, from the lowest: compound 1; then compound 4; then compound 3; then compound 2.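

In this assay the change to 4-bromophenoxy gives a 7.4-fold lower number from compound 3 to compound 4 (0.87 log units; beyond the scatter) and so recovers most of the ground lost in a 15-fold higher number from compound 1 to compound 3 (1.18 log units; beyond the scatter) even with an added oxygen in the chain. With the bromo present on both sides, the chain oxygen can now be read on its own as a 2.0-fold higher number from compound 1 to compound 4 (0.31 log units; beyond the scatter) and this modest step, beyond the scatter, shows that the position accepts 4-bromophenoxy in place of 4-bromophenyl at a small cost. No measurement on hand accounts for either step.

The compounds shown leave open whether the chain oxygen would have a similar effect on a ring without the bromo. They also leave open whether a chloro or a methoxy in place of the bromo, or a longer chain, would hold the number near that of compound 4.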